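Removing the tert-butyl: expected effect on cell viability

The compounds below may be only part of what the source reports. "The series", "measured", "known", "first", "only" and "open" are said of these compounds alone.

Three compounds have readings in an ADME assay on TERT-RPE1 cells (Homo sapiens) for cytotoxicity, read by MTT assay, with a stated time of 72 h; on this read-out higher numbers stand for weaker inhibition and lower numbers for stronger inhibition. Compound 1 `C=C1CN/C(=N/c2ccccc2)S1` gives only a limit in this assay, > 100000 nM. Compound 2 `COc1ccc(/C=C2\S/C(=N\c3ccc(C(C)(C)C)cc3)N(C)C2=O)cc1` gives 46700 nM in this assay, the higher of the two numbers. Compound 3 `COc1ccc(/C=C2/CN(C)/C(=N/c3ccc(Cl)cc3)S2)cc1` gives 39600 nM in this assay, and the gap between these two numbers lies within the scatter, so no order can be read from them. Among the compounds with values here, no pair of measured compounds differs in a single place, so no measured step is available in this assay.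

Compound 4 `COc1ccc(/C=C2\S/C(=N\c3ccccc3)N(C)C2=O)cc1` is the next compound. It differs from compound 2 as follows: hydrogen in place of tert-butyl on an aromatic carbon.

Within the data shown here, with no measured step to lean on, the expectation rests on the two numbers alone, which sit close together despite different substituents. With the tert-butyl gone, the expected step is a 1.3-fold higher number from compound 2 to compound 4 (0.11 log units; within the scatter), small and, if anything, toward a higher number. For compound 4 the estimated value in this assay is 60000 nM, with a range from 25000 nM to 150000 nM.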

Compound 4, half-maximal inhibitory concentration: > 100000 nM
Compound 4: only a limit was reported; the forecaster's own chance of this, stated with the estimate: 30%; middle value at least 1.6-fold (0.22 log units) from the limit.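

In this assay, within the data shown here, hydrogen in place of tert-butyl gives an at least 2.1-fold higher number from compound 2 to compound 4 (0.33 log units; beyond the scatter), the first single-place step, which shows that this position, para to a large group, bears on the reading and that the tert-butyl goes with the stronger inhibition of this pair. Compound 4 gives > 100000 nM, which is a limit and not a number. The step is therefore only a lower bound, because compound 4 reads at the top of the measurable range: the limit of > 100000 nM in this assay, at which 2 of the 4 values shown sit.

This single pair does not show whether the reading tracks the tert-butyl specifically or any group at this carbon; an ethyl, an amine or a carboxylic acid there would separate those cases. On these data alone, whether the same change acts alike on the core of compound 3 also remains open.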